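Halogen swap on the sulfonyl aryl of compound 1

The compounds below may be only part of what the source reports. "The series", "measured", "known", "first", "only" and "open" are said of these compounds alone.

Compound 1 `COc1ccc(-c2c(S(=O)(=O)c3cc(F)cc(F)c3)cnc3cc(F)ccc23)cc1` gives 1.51 mL/min in an ADME assay on microsomes from liver (Homo sapiens) for metabolic stability, tested at 2.5 uM (on this read-out lower numbers stand for slow clearance and higher numbers for fast clearance), the lowest of the three numbers: compound 3 `COc1cccc(-c2c(S(=O)(=O)c3cc(F)cc(F)c3)cnc3cc(F)ccc23)c1` gives 1.81 mL/min, and compound 2 `COc1cccc(-c2c(S(=O)(=O)c3ccc(C)c(C)c3)cnc3cc(F)ccc23)c1` gives 8.78 mL/min. The step of a 1.2-fold higher number from compound 1 to compound 3 (0.08 log units; within the scatter) is small. The step of a 4.9-fold lower number from compound 2 to compound 3 (0.69 log units; beyond the scatter) shows that the aryl on the sulfonyl sulfur moves the read-out well beyond the scatter.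

Compound 4 `COc1ccc(-c2c(S(=O)(=O)c3cc(Cl)cc(Cl)c3)cnc3cc(F)ccc23)cc1` differs from compound 1 by 3,5-dichlorophenyl in place of 3,5-difluorophenyl on a sulfonyl sulfur. Within the data shown here, no measured step replaces fluorine with chlorine, so the direction rests on the general sensitivity seen in a 4.9-fold lower number from compound 2 to compound 3 (0.69 log units; beyond the scatter). A modest rise is expected for compound 4, estimated at 2.6 mL/min, with a range of 1.2 mL/min to 5.6 mL/min, meaning the expected step of a 1.7-fold higher number from compound 1 to compound 4 (0.24 log units; within the scatter).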

Compound 4, intrinsic clearance in a liver preparation (reported as CLH), per the amount of preparation that the assay uses: 1 mL/min
For compound 4 the middle estimate is 2.6-fold (0.41 log units) above the measured one; the measured number lies below the stated range.
By their numbers in this assay, from the lowest: compounds 4, 1 and 3 (each within the scatter of the next); then compound 2.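

In this assay the step to 3,5-dichlorophenyl in place of 3,5-difluorophenyl on the sulfonyl sulfur is a 1.5-fold lower number from compound 1 to compound 4 (0.18 log units; within the scatter) and so gives no read-out difference beyond the scatter. The position that gave a 4.9-fold lower number from compound 2 to compound 3 (0.69 log units; beyond the scatter) therefore accepts this exchange of fluorine for chlorine in the 4-methoxyphenyl compounds. Nothing at hand gives a reason for this result.

Open, on these data alone, is whether an amine or a carboxylic acid on this aryl would keep the number low. Also open, as far as these compounds go, is whether 3,5-dichlorophenyl behaves alike with 3-methoxyphenyl on the shared core.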